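A few compounds are considered here, and "the series" means these few. Any claim that something is new, unique, unknown or untested is made for them only; others in the source may bear on it.

Measured compounds:
- compound 1 `COc1ccc(OC)c(/C=C/C(=O)Nc2cc3c(Nc4ccc(F)c(Cl)c4)ncnc3cc2O[C@H]2CCOC2)c1`: 36300 nM
- compound 2 `O=C(/C=C/c1ccc([N+](=O)[O-])cc1)Nc1cc2c(Nc3ccc(F)c(Cl)c3)ncnc2cc1O[C@H]1CCOC1`: 26700 nM
- compound 3 `O=C(/C=C/c1ccc(Br)cc1)Nc1cc2c(Nc3ccc(F)c(Cl)c3)ncnc2cc1O[C@H]1CCOC1`: 32400 nM

All three were read in a functional assay on MCF7 cells (Homo sapiens) for cytotoxicity, read by MTT assay, with a stated time of 72 h; on this read-out lower numbers stand for stronger inhibition and higher numbers for weaker inhibition. Compound 1 gives the highest of the three numbers, but its steps to the others are both small: a 1.4-fold lower number from compound 1 to compound 2 (0.13 log units; within the scatter) and a 1.1-fold lower number from compound 1 to compound 3 (0.05 log units; within the scatter). Between the other two, a 1.2-fold higher number from compound 2 to compound 3 (0.08 log units; within the scatter). On these numbers the three compounds are not separable.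

Compound 4 `O=C(/C=C/c1cc(Br)c(O)c(Br)c1)Nc1cc2c(Nc3ccc(F)c(Cl)c3)ncnc2cc1O[C@H]1CCOC1` has not been measured. Relative to compound 1 the change is 3,5-dibromo-4-hydroxyphenyl in place of 2,5-dimethoxyphenyl on a double-bonded chain carbon bound to a double-bonded chain carbon. For the measured compounds named here, the step that bears most directly on it is the one from compound 1 to compound 3, where a 4-bromophenyl also replaced the 2,5-dimethoxyphenyl on the double-bonded chain carbon and the number stayed within the scatter; the step from compound 1 to compound 2 points the same way. Going by the values given here, no measured pair shows what the hydroxy group adds. Compound 4 is therefore expected to sit close to compound 1, with a 1.2-fold lower number from compound 1 to compound 4 (0.08 log units; within the scatter) as a step not beyond the scatter. The estimate for compound 4 in this assay is 30000 nM, within the range 12000 nM to 75000 nM.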

Compound 4, half-maximal inhibitory concentration: 30600 nM
Compound 4: the middle estimate sits 1.0-fold (0.01 log units) below what was measured; low and high end bracket the measured number.
By their numbers in this assay, from the lowest: compounds 2, 4, 3 and 1 (each within the scatter of the next).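

In this assay, for the compounds shown here, the 3,5-dibromo-4-hydroxyphenyl group, the only aryl group of the four with a hydrogen-bond donor, gives a 1.2-fold lower number from compound 1 to compound 4 (0.07 log units; within the scatter) and a 1.1-fold lower number from compound 3 to compound 4 (0.02 log units; within the scatter) and a 1.1-fold higher number from compound 2 to compound 4 (0.06 log units; within the scatter), so all three new steps stay within the scatter. On a double-bonded chain carbon bound to a double-bonded chain carbon, a hydroxy group together with two bromo groups therefore does not separate compound 4 from the 2,5-dimethoxyphenyl, 4-bromophenyl or 4-nitrophenyl compounds, and all four remain one group on this read-out. No evidence is at hand that bears on this flat result.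

No pair shown isolates the hydroxy group from the two bromo groups. As far as these compounds go, whether an amine or a carboxylic acid on the phenyl ring, or a longer chain in place of the ethenyl link, would move the number beyond the scatter stays open.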